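This account rests on a few compounds, and the source may have more. Where it says the series, first, only, none or still open, it means among the compounds named here.

Measured compounds:
- compound 1, `O=c1[nH]cc(S(=O)(=O)Nc2cccc(-c3cn(-c4ccccc4)nn3)c2)c(=O)[nH]1`: 22500 nM
- compound 2, `O=c1[nH]cc(S(=O)(=O)Nc2cccc(-c3cn(-c4cccc(F)c4)nn3)c2)c(=O)[nH]1`: "not toxic" (no number reported)

In an ADME assay on GES1 cells (Homo sapiens) for cytotoxicity, read by MTT assay, with a stated time of 24 h (a lower number here means that less compound is tolerated, a higher number that more compound is tolerated), compound 1 gives 22500 nM. In this assay compound 2 is reported only as "not toxic" (no number reported), so no single number marks where compound 2 stands, and the gap to compound 1 cannot be put in figures. Compound 3, `O=c1[nH]cc(S(=O)(=O)Nc2cccc(-c3cn(-c4ccc(Cl)cc4)nn3)c2)c(=O)[nH]1`, has not been measured. It differs from compound 2 by 4-chlorophenyl in place of 3-fluorophenyl on an aromatic nitrogen. Among the compounds with values here, no comparable step exists among the measured pair, so in this assay a shift no larger than the scatter is expected in either direction. Compound 3 is estimated at 35000 nM, within 12000 nM to 120000 nM.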

Compound 3, half-maximal cytotoxic concentration: 11300 nM
Beside the measured number, compound 3's estimate is 3.1-fold (0.49 log units) above it; the measured number lies below the stated range.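

With 4-chlorophenyl on the aromatic nitrogen, the series gains a second number in this assay, and swapping hydrogen for chloro on an aromatic carbon gives a 2.0-fold lower number from compound 1 to compound 3 (0.30 log units; within the scatter), so this single change does not separate the two compounds. The step between compound 2 and compound 3 cannot be read, as compound 2 has only a verbal result. No measurement shown explains these readings. The compounds shown leave open how a phenyl ring carrying an amine or a carboxylic acid would read at this position.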